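A few compounds are considered here, and "the series" means these few. Any claim that something is new, unique, unknown or untested is made for them only; others in the source may bear on it.

Going by the values given here, in a functional assay on HT-29 cells (Homo sapiens) for antiproliferative activity, read by XTT assay, with a stated time of 72 h (a higher number here means a weaker inhibitor, a lower number a stronger inhibitor), compound 1 `C=C(C)CCC[C@]1(C)C2=CCC[C@](C)(C[C@H](OC(C)=O)C3=CC(=O)OC3O)[C@H]2CC[C@H]1C` gives 4200 nM, the lower of the two numbers so far. Compound 2 `CC(C)=CCC[C@]1(C)C2=CCC[C@](C)(CC(=O)c3ccoc3)[C@H]2CC[C@H]1C` gives 82300 nM, a weaker result beyond the scatter. Compound 3 `C=C(C)CCC[C@]1(C)C2=CCC[C@](C)(C[C@@H](OC(C)=O)C3=CC(=O)OC3O)[C@H]2CC[C@H]1C` has the same atoms and bonds as compound 1: the two compounds have the same atoms and bonds; at least one stereo element is drawn with a configuration in one of them and without one in the other: 1 of 6 stereo elements differ; a stereocentre at a saturated chain carbon is drawn S in compound 1 and R in compound 3. A stereocentre at a saturated chain carbon is drawn S in compound 1 and R in compound 3. Among the compounds with values here, no measured pair shows the size of such a change, so in this assay no step beyond the scatter is expected, and no firm direction. The estimated step is a 1.2-fold higher number from compound 1 to compound 3 (0.08 log units; within the scatter). The expected value for compound 3 is 5000 nM, with an estimated range of 1800 nM to 14000 nM.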

Compound 3, half-maximal inhibitory concentration: 2900 nM
Beside the measured number, compound 3's estimate is 1.7-fold (0.24 log units) above it; the range from low to high includes it.
By their numbers in this assay, from the lowest: compounds 3 and 1 (each within the scatter of the next); then compound 2.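

Changing the saturated chain carbon from S to R gives a 1.4-fold lower number from compound 1 to compound 3 (0.16 log units; within the scatter) in this assay, the first step read at this position. The configuration at this carbon therefore shows no effect beyond the scatter in this pair, and the stereocentre has no demonstrated influence on the read-out here. One caveat applies to this reading: the fact that one of compounds 1 and 3 is drawn with a defined configuration and the other without, at the place where they differ.

Still open, as far as these compounds go, is whether this insensitivity to configuration holds when an amine or a carboxylic acid sits on this carbon. The pair also leaves open how far it extends to other stereocentres of the shared core.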